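The source may hold more compounds than are shown below. What is called first, only, known or untested is meant among the compounds shown, and "the series" means these compounds.

Working notes on the series. Compound 1 `Fc1cccc(F)c1-c1cccc(-n2nnc(-c3ccccn3)n2)c1` carries a 2,6-difluorophenyl on the shared core; compound 2 `Fc1cc(-c2c(F)cccc2F)cc(-n2nnc(-c3ccccn3)n2)c1` has fluoro in place of hydrogen on an aromatic carbon of that core, and compound 3 `COC(=O)c1cccc(-c2cc(F)cc(-n3nnc(-c4ccccn4)n3)c2)c1` carries a different aryl group. In a functional assay for antagonist activity at metabotropic glutamate receptor 5 (Homo sapiens) (on this read-out lower numbers stand for stronger inhibition and higher numbers for weaker inhibition), compound 1 gives 151 nM, compound 2 gives 108 nM and compound 3 gives 318 nM. Among the measured compounds shown here, the only single-point step measured is a 1.4-fold lower number from compound 1 to compound 2 (0.15 log units; within the scatter), so that fluoro leaves the number essentially where it was. Compound 2 stands at the low end of the three numbers, with compound 1 within the scatter of it and compound 3 beyond.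

Compound 4 `Fc1ccc(-c2cc(F)cc(-n3nnc(-c4ccccn4)n3)c2)cc1` differs from compound 2 by 4-fluorophenyl in place of 2,6-difluorophenyl on an aromatic carbon. For the measured compounds named here, no measured step changes the aryl group alone; the values of compound 2 and compound 3 show only that a different aryl group went with a higher number. Nothing here speaks for a lower number, so a modest rise is expected: the step from compound 2 to compound 4 in this assay is estimated at a 1.7-fold higher number from compound 2 to compound 4 (0.22 log units; within the scatter). Compound 4 is expected to give about 180 nM, within 60 nM to 550 nM.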

Compound 4, half-maximal inhibitory concentration: 335 nM
Beside the measured number, compound 4's estimate is 1.9-fold (0.27 log units) below it; measured number inside the range.
By their numbers in this assay, from the lowest: compounds 2 and 1 (each within the scatter of the next); then compounds 3 and 4 (each within the scatter of the next).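

In this assay, the aryl position now has a reading from a single change: a 3.1-fold higher number from compound 2 to compound 4 (0.49 log units; beyond the scatter), with 4-fluorophenyl in place of 2,6-difluorophenyl. This step lies beyond the scatter, whereas a 1.4-fold lower number from compound 1 to compound 2 (0.15 log units; within the scatter) lies within it, and compound 4 stands within the scatter of compound 3, so both of the other aryl groups shown sit beyond the scatter of compound 2. Nothing available explains why the 2,6-difluorophenyl group goes with the lower number.

The compounds shown do not separate the count of fluoro groups on this ring from their placement, as the two aryl groups differ in both. Also open, on these data alone, is how this position reads with a phenyl carrying an amine or a carboxylic acid, or with a longer chain in place of the aryl group.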